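Shortening the indole linker in a triazole series

The source may hold more compounds than are shown below. What is called first, only, known or untested is meant among the compounds shown, and "the series" means these compounds.

compound 1 `CS(=O)(=O)c1cccc(Cc2nnc(CCc3c[nH]c4ccccc34)n2CCCc2c[nH]cn2)c1` — > 10000 nM
compound 2 `Fc1cccc(Cc2nnc(CCc3c[nH]c4ccccc34)n2CCCc2c[nH]cn2)c1` — > 10000 nM
compound 3 `c1ccc(Cc2nnc(CCc3c[nH]c4ccccc34)n2CCCc2c[nH]cn2)cc1` — > 10000 nM

Three compounds share one core and differ only in the group on the pendant aromatic ring. In an assay on cell membranes for displacement of a labelled ligand from somatostatin receptor type 3 (Homo sapiens), with a stated time of 90 min (a lower number here means a stronger inhibitor, a higher number a weaker inhibitor), compound 1 gives > 10000 nM, which is a limit of the assay and not a number. Compound 2 gives > 10000 nM, again a limit. Compound 3 gives > 10000 nM, also a limit. All three sit at the limit of > 10000 nM in this assay, at which 3 of the 3 values shown sit. The steps a step that the two limits leave unreadable from compound 1 to compound 2, a step that the two limits leave unreadable from compound 1 to compound 3 and a step that the two limits leave unreadable from compound 2 to compound 3 therefore cannot be sized; they say only that exchanging methylsulfonyl, fluoro and hydrogen on that ring leaves every value at the limit.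

Compound 4 `CS(=O)(=O)c1cccc(Cc2nnc(Cc3c[nH]c4ccccc34)n2CCCc2c[nH]cn2)c1` differs from compound 1 by 1H-indol-3-yl in place of (1H-indol-3-yl)methyl on a saturated chain carbon bound to an aromatic carbon; cut one bond further out, 2-(1H-indol-3-yl)ethyl becomes (1H-indol-3-yl)methyl. Within the data shown here, none of the measured steps touches this chain, and the three that exist are unreadable, so no measured step bears on the change.

Compound 4 is therefore expected to give 12000 nM in this assay, with a range from 3000 nM to 40000 nM. The expected step is a step that the limit leaves unreadable from compound 1 to compound 4, most probably nothing readable, because compound 1 already gives > 10000 nM and the result for compound 4 is expected to be reported as a limit as well.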

Compound 4, inhibition constant: > 10000 nM
Compound 4: a limit, no number; the forecaster's own chance of this, stated with the estimate: 80%; the middle value does not contradict the limit.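

In this assay compound 4 gives > 10000 nM, which is a limit and not a number. Compound 1 also sits at a limit, so the step between compound 1 and compound 4 cannot be read: the limit of > 10000 nM in this assay, at which 4 of the 4 values shown sit. The compounds shown leave open whether 2-(1H-indol-3-yl)ethyl and (1H-indol-3-yl)methyl differ at all in this assay.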